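A few compounds are considered here, and "the series" means these few. Any claim that something is new, unique, unknown or untested is made for them only; others in the source may bear on it.

Three ureas that share one core have been examined in an ADME assay on Raji cells (Homo sapiens) for cytotoxicity, with a stated time of 72 h; on this read-out lower numbers stand for an effect already at smaller amounts and higher numbers for an effect only at larger amounts of compound. Compound 1 `Cc1cc(NC(=O)Nc2ccc(C)c(Cl)c2)c2ccccc2n1` gives only the limit of the test, > 25000 nM. Compound 3 `Cc1cc(NC(=O)Nc2cc(F)ccc2F)c2ccccc2n1` likewise stops at a limit, > 25000 nM. Compound 2 `Cc1cc(NC(=O)Nc2ccc(C(=O)O)cc2)c2ccccc2n1` also returns a limit rather than a number, > 25000 nM, so it stands at the same edge as the other two. The picture so far is simply (the limit of > 25000 nM in this assay, at which 3 of the 3 values shown sit).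

Compound 4 `COC(=O)c1ccc(NC(=O)Nc2cc(C)nc3ccccc23)cc1` has not been measured. Compared with compound 2 it carries methyl in place of hydrogen on an oxygen next to a carbonyl group. With no measured step between any two of these compounds to lean on, the step expected for a step that the limit leaves unreadable from compound 2 to compound 4 is none beyond the usual scatter. Compound 4 is therefore estimated at about 30000 nM, somewhere between 10000 nM and 100000 nM, and most likely once more reported only as a limit.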

Compound 4, half-maximal effective concentration: 17000 nM
For compound 4 the middle estimate is 1.8-fold (0.25 log units) above the measured one, within the range that was stated.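

Changing carboxy to methoxycarbonyl comes with an at least 1.4-fold lower number from compound 2 to compound 4 (0.16 log units; that floor lies within the scatter). From the compounds shown here alone, the true size of this step stays unknown, and the floor alone does not show a change larger than ordinary scatter. Still, this position yields the first readable value in this assay, with the remaining compounds at the edge of the test: the limit of > 25000 nM in this assay, at which 3 of the 4 values shown sit.

Open, going by these compounds, is whether an ethyl ester, a primary amide or a nitrile in this place would give a number, and how any such number would compare with that of compound 4.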